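The source may hold more compounds than are shown below. What is called first, only, known or untested is meant among the compounds shown, and "the series" means these compounds.

Measured in a functional assay on HT-29 cells (Homo sapiens) for inhibition, read by MTT assay, with a stated time of 48 h; a higher number here means a weaker inhibitor, a lower number a stronger inhibitor:
Compound 1 `COc1cc(-c2nnc(SCc3ccc(C)cc3)n2-c2ccc(N(C)C)cc2)cc(OC)c1OC`: 27500 nM
Compound 2 `COc1ccc(C(=O)CSc2nnc(-c3cc(OC)c(OC)c(OC)c3)n2-c2ccc(N(C)C)cc2)cc1O`: > 60000 nM

Going by the values given here, the second entry is a limit and not a number, so compound 2 has no exact position: the only evidence is the limit of > 60000 nM in this assay, at which 1 of the 2 values shown sits. Compound 3 `COc1cc(-c2nnc(SCC(=O)c3ccc4ccccc4c3)n2-c2ccc(N(C)C)cc2)cc(OC)c1OC` carries naphthalen-2-yl in place of 3-hydroxy-4-methoxyphenyl on a carbonyl carbon, with the rest of the structure unchanged: naphthalen-2-yl in place of 3-hydroxy-4-methoxyphenyl on a carbonyl carbon. Among the compounds with values here, one measured step bears on this, an at least 2.1-fold higher number from compound 1 to compound 2 (0.33 log units; beyond the scatter). Going by these compounds, that step ends at a limit, so its full size is unknown. Compound 3 keeps the carbonyl but gives up the 3-hydroxy-4-methoxyphenyl group that marks the upper end of that step, so a move back towards the number of compound 1 at 27500 nM seems likely. The expected step is an at least 2.4-fold lower number from compound 2 to compound 3 (0.38 log units; beyond the scatter), towards a stronger inhibitor. For compound 3 the estimated value is 25000 nM, with an expected range of 9000 nM to 60000 nM.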

Compound 3, half-maximal inhibitory concentration: > 60000 nM
Compound 3 gave a limit, no number; the forecaster's own chance of this, stated with the estimate: 25%; middle value at least 2.4-fold (0.38 log units) away from the limit.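

In this assay compound 3 gives > 60000 nM, which is a limit of the assay and not a number. Compound 2 and compound 3 both end at a limit, so the step between them cannot be read: the limit of > 60000 nM in this assay, at which 2 of the 3 values shown sit. Setting (naphthalen-2-yl)carbonyl in place of 4-methylphenyl on the saturated chain carbon bound to a sulfur gives an at least 2.1-fold higher number from compound 1 to compound 3 (0.33 log units; beyond the scatter), so the higher number is no longer tied to the 3-hydroxy-4-methoxyphenyl group alone, as two different rings on the carbonyl carbon now go the same way.

Going by these compounds, how far compound 2 and compound 3 actually lie from compound 1 remains open, as does any order between them. Also open, on these data alone, is whether a morpholine or a plain methyl on the carbonyl carbon would give a readable number.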